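From ethyl to 3-methylphenyl on an aromatic nitrogen

The source may hold more compounds than are shown below. What is called first, only, known or untested is meant among the compounds shown, and "the series" means these compounds.

Compound 1 `CCn1ccnc1-c1cc(OC)c(OC)c(OC)c1` carries an ethyl group on an aromatic nitrogen. In a functional assay on HCT-15 cells (Homo sapiens) for antiproliferative activity, read by MTT assay, with a stated time of 72 h (on this read-out lower numbers stand for stronger inhibition and higher numbers for weaker inhibition), compound 1 returns > 100000 nM, which is a limit of the assay and not a number.

Compound 4 `COc1cc(-c2nccn2-c2cccc(C)c2)cc(OC)c1OC` has not yet been measured. Its change from compound 1 is 3-methylphenyl in place of ethyl on an aromatic nitrogen.

Within the data shown here, no measured pair in this small set differs in one place alone, so the expectation has only indirect support. Two other compounds with a ring-containing group on that nitrogen do give numbers in this assay: compound 2 `COc1ccc(-n2ccnc2-c2cc(OC)c(OC)c(OC)c2)cc1[N+](=O)[O-]` gives 1000 nM, and compound 3 `COc1cc(-c2nccn2-c2ccc3cc[nH]c3c2)cc(OC)c1OC` gives 4000 nM. On the strength of those two values, a large step toward stronger inhibition is expected, well beyond the scatter. The expected step is an at least 20-fold lower number from compound 1 to compound 4 (1.30 log units; beyond the scatter). For compound 4 the estimated value is 5000 nM, with an expected range from 800 nM to 40000 nM.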

Compound 4, half-maximal inhibitory concentration: 1600 nM
The estimate for compound 4 lay 3.1-fold (0.49 log units) above the measured number, and the stated range covers the measured number.
By their numbers in this assay, from the lowest: compounds 2 and 4 (each within the scatter of the next); then compound 3. At a limit, above all of these: compound 1.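

Among these compounds, for the first time here, two compounds differ in one place alone, and in this assay 3-methylphenyl in place of ethyl on an aromatic nitrogen brings an at least 62-fold lower number from compound 1 to compound 4 (1.79 log units; beyond the scatter) as a step that can be read directly. At this nitrogen, the change exchanges a group with no ring for one six-membered aromatic ring of carbon only, and no hydrogen-bond donor or acceptor enters or leaves. On these data alone, the true size of the step stays unknown, since compound 1 stands at a limit of the assay and not at a number: the limit of > 100000 nM in this assay, at which 1 of the 4 values shown sits.

The compounds shown leave open whether the ring alone would carry this step, as a plain phenyl would show, or whether the methyl takes part. They also leave open how a longer chain such as butyl or a benzyl group would read on this nitrogen.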